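The source may report more compounds than this note shows. Statements on the series, on what has been measured and on what is new or still open speak of the compounds shown alone.

Compound 3 `CCN(CC)S(=O)(=O)c1ccc(S(=O)(=O)N2CCC[C@@H](C(=O)N3CCOCC3)C2)cc1` gives the lowest number of the three in a functional assay on BXPC-3 cells (Homo sapiens) for inhibition, read by MTT assay, with a stated time of 7 days (a lower number here means a stronger inhibitor, a higher number a weaker inhibitor), at 790 nM; compound 2 `CCN(CC)S(=O)(=O)c1ccc(S(=O)(=O)N2CCC[C@@H](C(=O)N[C@H]3CC[C@H](OC)CC3)C2)cc1` gives 2000 nM and compound 1 `CCN(CC)S(=O)(=O)c1ccc(S(=O)(=O)N2CCC[C@@H](C(=O)NC3COC3)C2)cc1` gives 13800 nM in this assay. Compound 4 `CCN(CC)S(=O)(=O)c1ccc(S(=O)(=O)N2CCC[C@@H](C(=O)N[C@H]3CC[C@@H](OC)CC3)C2)cc1` differs from compound 3 by (4-methoxycyclohexyl)amino in place of morpholin-4-yl on a carbonyl carbon, the entering group being a stereoisomer of the corresponding group in compound 2. The measured step that bears most directly on this change is a 2.5-fold lower number from compound 2 to compound 3 (0.40 log units; beyond the scatter), which compound 4 would essentially run in reverse; a 17-fold lower number from compound 1 to compound 3 (1.24 log units; beyond the scatter) and a 6.9-fold lower number from compound 1 to compound 2 (0.84 log units; beyond the scatter) point the same way. A modest rise in this assay is therefore expected, of roughly a 2.5-fold higher number from compound 3 to compound 4 (0.40 log units; beyond the scatter). Compound 4 is estimated at 2000 nM, with a range of 800 nM to 5000 nM.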

Compound 4, half-maximal inhibitory concentration: 2150 nM
The estimate for compound 4 lay 1.1-fold (0.03 log units) below the measured number; measured number inside the range.
By their numbers in this assay, from the lowest: compound 3; then compounds 2 and 4 (each within the scatter of the next); then compound 1.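

Inverting the configuration of the (4-methoxycyclohexyl)amino group gives a 1.1-fold higher number from compound 2 to compound 4 (0.03 log units; within the scatter) in this assay, so this read-out does not separate the two forms, and the comparison isolates a single variable: the fact that compounds 2 and 4 differ only in the configuration as drawn. The other two steps, a 2.7-fold higher number from compound 3 to compound 4 (0.43 log units; beyond the scatter) and a 6.4-fold lower number from compound 1 to compound 4 (0.81 log units; beyond the scatter), show that the standing of this group relative to morpholin-4-yl and to (oxetan-3-yl)amino holds for both drawn forms. The compounds shown leave open how a piperidin-1-yl or a 4-methylpiperazin-1-yl group on this carbonyl carbon would read, and therefore whether the ring oxygen of morpholin-4-yl matters to its lower number.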